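Benzoylation of the exocyclic amine in a quinazoline series

The source may hold more compounds than are shown below. What is called first, only, known or untested is meant among the compounds shown, and "the series" means these compounds.

Of the compounds shown here, two have so far been measured in a functional assay on MCF7 cells (Homo sapiens) for antiproliferative activity, read by MTT assay, with a stated time of 48 h; a higher number here means a weaker inhibitor, a lower number a stronger inhibitor. Compound 1, the open-chain amide `Cc1ccc(C(=O)Nc2ccc(Cl)cc2C(N)=O)cc1`, gives 5.39 ug/mL. Compound 2, the ring-closed analogue `Cc1ccc(-c2nc(N)c3cc(Cl)ccc3n2)cc1`, gives 3.76 ug/mL. These two numbers sit within the usual scatter of one another, so compound 2 stands at a value that cannot be set apart from that of compound 1 on the evidence at hand.

Compound 3, `Cc1ccc(-c2nc(NC(=O)c3ccccc3)c3cc(Cl)ccc3n2)cc1`, has not yet been tested. It differs from compound 2 by benzoyl in place of hydrogen on a nitrogen on an aromatic ring; cut one bond further out, the change reads amino to benzamido. Among the compounds with values here, no measured pair in this set shows what such a change does in this assay, so the expectation rests on the only two numbers available. In the absence of such a precedent, the step is expected to be modest and to stay close to the scatter, with little pull in either direction. The value of compound 3 is therefore estimated at 3 ug/mL, within a range from 1 ug/mL to 9 ug/mL, which corresponds to an expected step of a 1.3-fold lower number from compound 2 to compound 3 (0.10 log units; within the scatter).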

Compound 3, half-maximal inhibitory concentration: 16.1 ug/mL
The estimate for compound 3 lay 5.4-fold (0.73 log units) below the measured number, and the stated range ends below it.
By their numbers in this assay, from the lowest: compounds 2 and 1 (each within the scatter of the next); then compound 3.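

In this assay, within the data shown here, benzoyl in place of hydrogen on this nitrogen brings a 4.3-fold higher number from compound 2 to compound 3 (0.63 log units; beyond the scatter) and gives the only comparison here between compounds that differ in one place. The change from amino to benzamido therefore shows that this nitrogen on an aromatic ring does not tolerate every substituent without consequence, and that this one moves the read-out toward a weaker inhibitor by more than the scatter. No measurement at hand accounts for the shift, so the result records its direction and size but gives no reason for either.

The compounds shown leave open whether the shift follows from the carbonyl or from the added aromatic ring, a question that an acetyl group or a benzyl group on the same nitrogen could help to separate. They also leave open whether the free amino group itself matters, or whether a methylamino group, a dimethylamino group or a substituted benzoyl group would give a number closer to that of compound 2 or further from it.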